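This account rests on a few compounds, and the source may have more. Where it says the series, first, only, none or still open, it means among the compounds named here.

Measured in a functional assay on cells (Homo sapiens) for antiproliferative activity, read by MTT assay, with a stated time of 48 h; a lower number here means a stronger inhibitor, a higher number a weaker inhibitor:
Compound 1 `N#Cc1nc2c(-c3nc4ccccc4[nH]3)c(N)n(CCO)c2nc1C#N`: > 50000 nM, a limit of the assay
Compound 2 `CN1CCN(CCCn2c(N)c(-c3nc4ccccc4[nH]3)c3nc(C#N)c(C#N)nc32)CC1`: 4520 nM

In this assay, for the measured compounds named here, compound 2 stands at 4520 nM, the only true number so far. Compound 3 `CCCCn1c(N)c(-c2nc3ccccc3[nH]2)c2nc(C#N)c(C#N)nc21` turns the 3-(4-methylpiperazin-1-yl)propyl of compound 2 into butyl: methyl in place of 4-methylpiperazin-1-yl on a saturated chain carbon, three bonds along the chain from an aromatic nitrogen. Going by the values given here, one measured step bears on this, an at least 11-fold lower number from compound 1 to compound 2 (1.04 log units; beyond the scatter), a large step that came with (4-methylpiperazin-1-yl)methyl in place of hydroxy. Compound 3 loses the 4-methylpiperazin-1-yl but gains no hydroxy, so a smaller step towards a higher number, a weaker inhibitor, is expected. The expected step is a 3.3-fold higher number from compound 2 to compound 3 (0.52 log units; beyond the scatter). For compound 3 the estimated value is 15000 nM, with an expected range of 4000 nM to 50000 nM.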

Compound 3, half-maximal inhibitory concentration: > 50000 nM
Compound 3 gave a limit, no number; the forecaster's own chance of this, stated with the estimate: 35%; at least 3.3-fold (0.52 log units) between middle value and limit.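

The change from 3-(4-methylpiperazin-1-yl)propyl to butyl gives an at least 11-fold higher number from compound 2 to compound 3 (1.04 log units; beyond the scatter) in this assay, so an alkyl chain of this kind on the aromatic nitrogen does not by itself keep the activity of compound 2. For the compounds shown here, the hydroxy of compound 1 is therefore not the only group at this position that goes with a limit rather than a number. The step between compound 1 and compound 3 cannot be read, as both are limits of the assay: the limit of > 50000 nM in this assay, at which 2 of the 3 values shown sit.

As far as these compounds go, it stays open whether 4-methylpiperazin-1-yl is needed or whether a simpler amine such as dimethylamino would serve in the same place. From the compounds shown here alone, a longer chain carrying 4-methylpiperazin-1-yl also remains open.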